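The compounds below may be only part of what the source reports. "The series", "measured", "known", "first", "only" and "open" are said of these compounds alone.

In an assay for inhibition of histone acetyltransferase KAT2B (Homo sapiens), read by TR-FRET, with a stated time of 10 min, tested at 50 uM (on this read-out higher numbers stand for more inhibition at the one concentration tested (going by the name of the read-out) and lower numbers for less inhibition), compound 1 `CCOc1ccccc1/C=C1\SC(=S)N(CCCCCC(=O)OC)C1=O` gives 9%. In this assay compound 2 `O=C(O)CCCCCN1C(=O)/C(=C2/C(=O)Nc3ccccc32)SC1=S` gives 9%, which stands level with compound 1 within the usual scatter of such measurements, so both show only slight inhibition on this read-out. Compound 3 `CCN1C(=O)/C(=C2\SC(=S)N(CCCCCC(=O)O)C2=O)c2ccccc21` differs from compound 2 in a single place: ethyl in place of hydrogen on an amide-type nitrogen in a ring. Within the data shown here, no measured pair shows a change of this kind, so its effect is unknown; the expectation is a step of about none beyond the scatter. Compound 3 is therefore estimated to give about 9%, with a range from -2% to 22%. This estimate corresponds to an expected step of no change at the digits printed from compound 2 to compound 3 (within the scatter).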

Compound 3, a percentage reported as inhibition, at one concentration (the size of the read-out at that concentration, not a potency): 6%
Beside the measured number, compound 3's estimate is 3 percentage points above it; the measured number falls inside the stated range.
By their numbers in this assay, from the lowest: compounds 3, 1 and 2 (each within the scatter of the next).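

In this assay, ethyl in place of hydrogen on an amide-type nitrogen in a ring gives a number 3 percentage points lower from compound 2 to compound 3 (within the scatter). Among these compounds, this is the first measured step at this position, and it shows that the hydrogen can give way to ethyl with no change beyond the scatter, though inhibition stays slight in both compounds. Nothing available explains this result. On these data alone, whether a benzyl group or a chain ending in an amine on this nitrogen would give a clearly different number remains open. A single step also cannot show how other groups at this position would behave on the shared core.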